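The compounds below may be only part of what the source reports. "The series", "measured", "known", "first", "only" and "open" are said of these compounds alone.

Measured so far:
- compound 1, `O=C(Nc1cccc(CNc2ncnc3ccccc23)c1)Nc1ccccc1F`, 33400 nM
- compound 2, `O=C(Nc1cccc(Cl)c1)Nc1cccc(CNc2ncnc3ccccc23)c1`, 19200 nM
- compound 3, `COc1cc2ncnc(NCc3cccc(NC(=O)Nc4ccccc4C)c3)c2cc1OC`, > 50000 nM

All three were tested in a functional assay on MGC-803 cells (Homo sapiens) for antiproliferative activity, read by MTT assay; on this read-out lower numbers stand for stronger inhibition and higher numbers for weaker inhibition. Compound 1 and compound 2 share a core and differ only in the group on an amide-type nitrogen; the change from 2-fluorophenyl to 3-chlorophenyl gives a 1.7-fold lower number from compound 1 to compound 2 (0.24 log units; within the scatter), so the two numbers cannot be told apart. Compound 3 carries a different core and stands at the edge of what the assay can report: the value given for compound 3 is a limit, not a number, as noted in the limit of > 50000 nM in this assay, at which 1 of the 3 values shown sits.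

Compound 4, `COc1cc2ncnc(NCc3cccc(NC(=O)Nc4cccc(C(F)(F)F)c4)c3)c2cc1OC`, has not yet been measured. It keeps the core of compound 3 and changes only the group on the amide-type nitrogen: 3-(trifluoromethyl)phenyl in place of 2-methylphenyl on an amide-type nitrogen. Within the data shown here, the one measured step that bears on it, from compound 1 to compound 2, is a swap of one substituted phenyl for another on the same kind of nitrogen, and it stayed within the scatter. By that precedent the step from compound 3 to compound 4 is expected to be small, an at least 1.1-fold lower number from compound 3 to compound 4 (0.04 log units; that floor lies within the scatter), with a fair chance that the assay again reports only a limit.

Compound 4 is therefore estimated at 45000 nM, within a range from 15000 nM to 150000 nM.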

Compound 4, half-maximal inhibitory concentration: > 50000 nM
Compound 4: only a limit was reported (the forecaster's own chance of this, stated with the estimate: 50%); middle value at least 1.1-fold (0.04 log units) from the limit.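

In this assay, compound 3 and compound 4 each return only a limit rather than a number, so no step between them can be read: the limit of > 50000 nM in this assay, at which 2 of the 4 values shown sit.

The compounds shown leave open whether any group on the amide-type nitrogen of this core can give a real number, and how far 3-(trifluoromethyl)phenyl itself matters.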